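This account rests on a few compounds, and the source may have more. Where it says the series, first, only, none or still open, it means among the compounds named here.

Among the measured compounds shown here, compound 2 `Cc1cc2c(C(C)C)ccc(C)c2cc1OC(=O)c1ccc(C(F)(F)F)cc1` gives 100% in a functional assay on PC-3 cells (Homo sapiens) for antiproliferative activity, read by sulforhodamine B assay, with a stated time of 48 h, tested at 50 uM (a lower number here means less inhibition, a higher number more inhibition at the concentration tested (going by the name of the read-out)), the higher of the two numbers measured so far. Compound 1 `CC1=CC[C@H](C(C)C)c2cc(C)c(OC(=O)c3ccc(C)cc3)cc21` gives 49.6% in this assay, a gap beyond the usual scatter. Compound 3 `Cc1cc2c(C(C)C)ccc(C)c2cc1OC(=O)c1ccc([N+](=O)[O-])cc1` has not yet been measured; it differs from compound 2 in one place: nitro in place of trifluoromethyl on an aromatic carbon. For the measured compounds named here, no measured step of this kind exists, so the change is expected to bring a small decrease in this assay, possibly none beyond the scatter. Compound 3 is estimated at 88%, within 62% to 100%. This expectation amounts to a step of a number 12 percentage points lower from compound 2 to compound 3 (beyond the scatter).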

Compound 3, a percentage reported as inhibition, at one concentration (the size of the read-out at that concentration, not a potency): 100%
Estimate against measurement, compound 3: 12 percentage points below; the range from low to high includes it.
By their numbers in this assay, from the lowest: compound 1; then compounds 2 and 3 (each within the scatter of the next).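

In this assay, nitro in place of trifluoromethyl on an aromatic carbon para to a large group brings no change at the digits printed from compound 2 to compound 3 (within the scatter). Among the compounds shown here, this is the first comparison of two groups at this position on the shared core, and at the single concentration tested the two groups are not told apart. Nothing available explains this result. On these data alone, it remains open whether an amine or a carboxylic acid at this position would give the same read-out, and whether compound 2 and compound 3 would separate at lower concentrations.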